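The source may report more compounds than this note shows. Statements on the series, on what has been measured and on what is new or still open speak of the compounds shown alone.

Compound 1 `O=S(=O)(Nc1ccc(-c2nc3ccccc3o2)cc1)c1cccs1` in an assay on isolated protein for inhibition of malate dehydrogenase, mitochondrial (Sus scrofa), with stated times of 45 min and 30 min (a higher number here means a weaker inhibitor, a lower number a stronger inhibitor), gives > 63000 nM, which is a limit of the assay rather than a number.
Compound 2 `Cc1ccccc1S(=O)(=O)Nc1ccc(-c2nc3ccccc3o2)cc1` gives > 63000 nM, again a limit.
Compound 3 `Cc1cccc(S(=O)(=O)Nc2ccc(-c3nc4ccccc4o3)cc2)c1` gives > 63000 nM, also a limit.

All three compounds share one core and differ only in the aromatic group attached to the sulfonyl sulfur. Because every value shown sits at the limit of > 63000 nM in this assay, at which 3 of the 3 values shown sit, none of the steps among them can be read: a step that the two limits leave unreadable from compound 1 to compound 2, a step that the two limits leave unreadable from compound 1 to compound 3 and a step that the two limits leave unreadable from compound 2 to compound 3. Compound 3 therefore stands at the limit, in the same position as the two other values shown, and cannot be placed above or below either of them.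

Compound 4 `O=S(=O)(Nc1ccc(-c2nc3ccccc3o2)cc1)c1ccc(Cl)cc1` differs from compound 3 in one place: 4-chlorophenyl in place of 3-methylphenyl on a sulfonyl sulfur. Going by the values given here, the measured steps that bear on this change are exchanges of one small aromatic group for another on the same sulfonyl sulfur, and all of them were unreadable, so no measured step shows that such an exchange moves inhibition at all. The expected step for a step that the limit leaves unreadable from compound 3 to compound 4 is therefore none beyond the scatter, with a real chance that this assay again returns only a limit. Compound 4 is estimated at 90000 nM, expected to fall between 30000 nM and 300000 nM.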

Compound 4, half-maximal inhibitory concentration: > 63000 nM
Compound 4: no number, only a limit (the forecaster's own chance of this, stated with the estimate: 85%); the middle value is on the limit's open side.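

Compound 4 also returns only a limit, so its steps from compound 1, compound 2 and compound 3 cannot be read, and these four compounds cannot be ranked: the limit of > 63000 nM in this assay, at which 4 of the 4 values shown sit. The compounds shown leave open whether any group on the sulfonyl sulfur of the shared core can give a readable number in this assay at all.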